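Ether-linked nitrophenyl in place of the methoxybenzamide

A few compounds are considered here, and "the series" means these few. Any claim that something is new, unique, unknown or untested is made for them only; others in the source may bear on it.

Measured compounds in a functional assay on PANC-1 cells (Homo sapiens) for inhibition, read by MTT assay, with a stated time of 24 h, tested at 10 uM; a lower number here means less inhibition, a higher number more inhibition at the concentration tested (going by the name of the read-out):
compound 1 `CCOc1cc(=O)n(CCCO)c2c1CC(C/C=C(\C)CCC=C(C)C)C(C)(C)C2`, 0.8%
compound 2 `CC(C)=CCC/C(C)=C/CC1Cc2c(OCCCNS(=O)(=O)c3ccc([N+](=O)[O-])cc3)cc(=O)n(CCCO)c2CC1(C)C`, 0%
compound 3 `COc1ccc(C(=O)NCCCOc2cc(=O)n(CCCO)c3c2CC(C/C=C(\C)CCC=C(C)C)C(C)(C)C3)cc1`, 14.1%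

Compound 3 stands highest of the three, beyond the scatter from both others. The steps leading to it are a number 13.3 percentage points higher from compound 1 to compound 3 (beyond the scatter) and a number 14.1 percentage points higher from compound 2 to compound 3 (beyond the scatter), both modest.

Compound 4 `CC(C)=CCC/C(C)=C/CC1Cc2c(OCCCOc3ccc([N+](=O)[O-])cc3)cc(=O)n(CCCO)c2CC1(C)C` differs from compound 3 in one place: 4-nitrophenoxy in place of ((4-methoxyphenyl)carbonyl)amino on a saturated chain carbon, three bonds along the chain from an oxygen on an aromatic ring. The step from compound 2 to compound 3 bears most directly, since compound 2 also carries a nitrophenyl on the same chain and sits at the bottom of the set; compound 1, without any group on that chain, is also low. Reversing toward a nitrophenyl group is therefore expected to give back most of the gain in this assay, and the step of a number 11.1 percentage points lower from compound 3 to compound 4 (beyond the scatter) is expected to be downward, roughly the size of the measured steps.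

Compound 4 is estimated at 3%, with a range of 0% to 14%.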

Compound 4, a percentage reported as inhibition, at one concentration (the size of the read-out at that concentration, not a potency): 9.8%
Beside the measured number, compound 4's estimate is 6.8 percentage points below it, within the range that was stated.
By their numbers in this assay, from the lowest: compounds 2, 1, 4 and 3 (each within the scatter of the next, the first and the last beyond it).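

In this assay, 4-nitrophenoxy on a saturated chain carbon, three bonds along the chain from an oxygen on an aromatic ring, gives a number 4.3 percentage points lower from compound 3 to compound 4 (within the scatter) and thus does not separate from the ((4-methoxyphenyl)carbonyl)amino group, even though the amide hydrogen is gone. Against the unsubstituted chain, the (4-nitrophenoxy)methyl change gives a number 9 percentage points higher from compound 1 to compound 4 (within the scatter), so this group does not separate from hydrogen either. No measurement at hand accounts for these steps.

On these data alone, whether an amine or a carboxylic acid at this chain position, or a longer chain carrying the 4-nitrophenoxy, would shift the read-out stays open. Potency also stays open, since each number comes from a single concentration.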